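Swapping dimethylamino for hydroxy in a sulfone series

The compounds below may be only part of what the source reports. "The series", "measured", "known", "first", "only" and "open" are said of these compounds alone.

The measurements come from a functional assay on DU-145 cells (Homo sapiens) for inhibition, read by trypan blue exclusion, with a stated time of 96 h; on this read-out higher numbers stand for weaker inhibition of growth and lower numbers for stronger inhibition of growth. Three compounds have numbers there so far. Compound 1, with the structure `Cc1cc(F)ccc1/C=C(/SCc1ccc(F)cc1)C(=O)c1ccc(Br)cc1`, gives 10000 nM in this assay. Compound 2, with the structure `COc1ccc(C(=O)/C(=C\c2ccc(Br)cc2)Sc2ccc(F)cc2)cc1`, reaches only the limit of the assay, > 100000 nM, which is not a number but the edge of what this assay can report; this is the case noted in the limit of > 100000 nM in this assay, at which 1 of the 3 values shown sits. Compound 3, with the structure `CN(C)c1ccc(/C=C(\C(=O)c2ccc(Br)cc2)S(=O)(=O)Cc2ccc(F)cc2)cc1`, gives 50000 nM in this assay. Of the two numbers shown, compound 3 has the higher one, meaning the weaker inhibition of growth, and its gap to compound 1 lies beyond the usual scatter of repeated measurements.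

The next compound follows a single change from compound 3. Compound 4, with the structure `O=C(/C(=C\c1ccc(O)cc1)S(=O)(=O)Cc1ccc(F)cc1)c1ccc(Br)cc1`, differs from compound 3 in one place: hydroxy in place of dimethylamino on an aromatic carbon. For the measured compounds named here, no measured pair in this set shows this same change, so its effect has to be guessed from compound 3 alone. The expected step from compound 3 to compound 4 in this assay is a 1.7-fold lower number from compound 3 to compound 4 (0.22 log units; within the scatter), a modest move toward stronger inhibition of growth that may well sit within the scatter. Compound 4 is therefore estimated at 30000 nM in this assay, with a range from 8000 nM to 100000 nM.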

Compound 4, concentration for 50% growth inhibition: 10000 nM
Estimate against measurement, compound 4: 3.0-fold (0.48 log units) above; the range from low to high includes it.
By their numbers in this assay, from the lowest: compounds 1 and 4 (each within the scatter of the next); then compound 3. At a limit, above all of these: compound 2.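

In this assay, putting hydroxy in place of dimethylamino gives a 5.0-fold lower number from compound 3 to compound 4 (0.70 log units; beyond the scatter), a move toward stronger inhibition of growth. For the compounds shown here, this is the first pair in the set that differs in only one place, so it is the first direct sign that the group on this aromatic carbon, para to a large group, can by itself shift the read-out by more than the usual scatter. The change removes a group of 3 heavy atoms with no hydrogen-bond donor and brings in a single oxygen with 1 hydrogen-bond donor, but nothing measured here says which of these differences matters or explains the step.

As far as these compounds go, what a plain amino group or a carboxylic acid on this same carbon would do remains open, so a single pair cannot show whether the gain belongs to hydroxy in particular or would come with other groups in place of dimethylamino. From the compounds shown here alone, it is also open whether the same swap would give a step of similar size if the sulfone were replaced by another link in the rest of the compound.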